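The compounds below may be only part of what the source reports. "The series", "measured", "known", "first", "only" and "open" are said of these compounds alone.

Compound 1 `O=C(Nc1ccc(Cl)cc1)Nc1ccc(Nc2ncnc3c2OCCN3)cc1`: 2280 nM
Compound 2 `COc1cccc(NC(=O)Nc2ccc(Nc3ncnc4c3OCCN4)cc2)c1`: 5290 nM

In an assay on isolated protein for inhibition of proto-oncogene tyrosine-protein kinase receptor Ret variant V804M (Homo sapiens), read by 33P incorporation, with stated times of 15 min and 40 min (on this read-out lower numbers stand for stronger inhibition and higher numbers for weaker inhibition), compound 1 gives 2280 nM and compound 2 gives 5290 nM. For the measured compounds named here, compound 2 stands highest of the two numbers so far; its nearest neighbour is compound 1, and the step of a 2.3-fold higher number from compound 1 to compound 2 (0.37 log units; beyond the scatter) is beyond the scatter, so compound 2 is the weaker of the two inhibitors here.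

Compound 3 `Cc1ccc(F)c(NC(=O)Nc2ccc(Nc3ncnc4c3OCCN4)cc2)c1` differs from compound 2 in one place: 2-fluoro-5-methylphenyl in place of 3-methoxyphenyl on an amide-type nitrogen. Going by the values given here, no measured step covers this particular exchange. Among the compounds with values here, the only step that bears on it is the one at the same amide-type nitrogen, a 2.3-fold higher number from compound 1 to compound 2 (0.37 log units; beyond the scatter), which shows that swapping one aryl group for another at this position can move the number by a modest amount in either direction. Since compound 3 carries a halogen-bearing ring, as compound 1 does, rather than the methoxy-bearing ring of compound 2, the expectation is a step of a 1.8-fold lower number from compound 2 to compound 3 (0.25 log units; within the scatter) toward a lower number, of roughly the size seen before. Compound 3 is therefore estimated at 3000 nM, within a range of 1200 nM to 8000 nM.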

Compound 3, half-maximal inhibitory concentration: 5110 nM
Compound 3: middle estimate off by 1.7-fold (0.23 log units), on the low side, and the stated range covers the measured number.
By their numbers in this assay, from the lowest: compound 1; then compounds 3 and 2 (each within the scatter of the next).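

In this assay, putting 2-fluoro-5-methylphenyl in place of 3-methoxyphenyl on the amide-type nitrogen leaves the number within the scatter (a 1.0-fold lower number from compound 2 to compound 3 (0.02 log units; within the scatter)), so compound 2 and compound 3 cannot be told apart, although the hydrogen-bond acceptor counted in 3-methoxyphenyl is absent from 2-fluoro-5-methylphenyl. The same group in place of 4-chlorophenyl gives a modest step beyond the scatter (a 2.2-fold higher number from compound 1 to compound 3 (0.35 log units; beyond the scatter)), which leaves compound 1 the strongest inhibitor of the three and shows that a halogen on this ring does not by itself go with the lower number, since compound 3 carries fluorine and still sits with compound 2. No independent evidence accompanies these numbers to say what sets 4-chlorophenyl apart from the other two aryl groups.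

The compounds shown leave open whether the lower number of compound 1 belongs to the chlorine itself or to where it sits, a question that a 3-chlorophenyl or a 4-fluorophenyl group would address. They also leave open how this nitrogen responds to anything other than a substituted phenyl, such as a pyridine ring, a cyclohexyl group or a longer alkyl chain.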